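Urea versus amide on the shared core of compound 2

The compounds below may be only part of what the source reports. "The series", "measured", "known", "first", "only" and "open" are said of these compounds alone.

Among the compounds with values here, compound 2 `COc1cc(-c2nn(-c3cccc(NC(=O)c4ccc(Cl)c(C(F)(F)F)c4)c3)cc2-c2ccncc2)ccc1Cl` is the weaker of the two compounds measured so far: in a functional assay on UACC-257 cells (Homo sapiens) for inhibition, read by sulforhodamine B assay, with a stated time of 48 h (a lower number here means a stronger inhibitor of growth, a higher number a weaker inhibitor of growth), compound 2 gives 7130 nM, the higher of the two numbers. Its nearest neighbour, compound 1 `COc1cc(-c2nn(-c3cccc(NC(=O)Nc4cccc(C(F)(F)F)c4)c3)cc2-c2ccncc2)ccc1Cl`, gives 923 nM in this assay; the step of a 7.7-fold higher number from compound 1 to compound 2 (0.89 log units; beyond the scatter) replaced a (3-(trifluoromethyl)phenyl)amino group with a 4-chloro-3-(trifluoromethyl)phenyl group on the carbonyl carbon, so the chloro substituent and the loss of the amino linker entered together. Compound 3 `COc1cc(-c2nn(-c3cccc(NC(=O)Nc4ccc(Cl)c(C(F)(F)F)c4)c3)cc2-c2ccncc2)ccc1Cl` carries the change (4-chloro-3-(trifluoromethyl)phenyl)amino in place of 4-chloro-3-(trifluoromethyl)phenyl on a carbonyl carbon: the amino linker returns, with one hydrogen-bond donor, while the chloro substituent is kept. Within the data shown here, only the step from compound 1 to compound 2 bears on this, and it points the other way. Among the measured compounds shown here, that step changed two things at once, and there is no measured pair in which the chloro substituent is the only difference. A fall toward the number of compound 1 is therefore expected, a 5.9-fold lower number from compound 2 to compound 3 (0.77 log units; beyond the scatter). For compound 3 the estimate in this assay is 1200 nM, within 400 nM to 3600 nM.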

Compound 3, concentration for 50% growth inhibition: 1210 nM
Compound 3: middle estimate off by 1.0-fold (0.00 log units), on the low side; measured number inside the range.
By their numbers in this assay, from the lowest: compounds 1 and 3 (each within the scatter of the next); then compound 2.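

With the chloro substituent and the 4-chloro-3-(trifluoromethyl)phenyl ring held constant, the amino linker on the carbonyl carbon is now the only difference, and it gives a 5.9-fold lower number from compound 2 to compound 3 (0.77 log units; beyond the scatter) in this assay. The chloro substituent is also isolated on the urea, where chloro in place of hydrogen on the aromatic carbon gives a 1.3-fold higher number from compound 1 to compound 3 (0.12 log units; within the scatter), so the gap in a 7.7-fold higher number from compound 1 to compound 2 (0.89 log units; beyond the scatter) tracks the loss of the amino linker and not the added chloro in these three compounds. No measurement is available that explains why the urea and the amide differ.

On these data alone, it remains open whether the urea nitrogen can give way to a carbamate oxygen or carry a methyl group on the same carbonyl carbon. As far as these compounds go, it is also open whether a nitrile in place of the chloro substituent would keep the number of the urea series.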